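Ethoxycarbonyl in place of cyano on the shared core

The source may report more compounds than this note shows. Statements on the series, on what has been measured and on what is new or still open speak of the compounds shown alone.

Three compounds have numbers in a functional assay on A549 cells (Homo sapiens) for inhibition, read by MTT assay; a higher number here means a weaker inhibitor, a lower number a stronger inhibitor. Compound 1 (`N#Cc1c(N)sc(C(=O)Nc2ccc(Cl)cc2)c1-c1ccccc1`) gives 700 nM, compound 2 (`N#CCC(=O)Nc1sc(C(=O)Nc2ccc(Cl)cc2)c(-c2ccccc2)c1C#N`) gives 1400 nM, and compound 3 (`N#Cc1c(N)sc(C(=O)Nc2ccccc2)c1-c1ccccc1`) gives 8280 nM, the highest number of the three. Compound 4 (`CCOC(=O)c1c(N)sc(C(=O)Nc2ccccc2)c1-c1ccccc1`) has not yet been measured. It differs from compound 3 by one change, ethoxycarbonyl in place of cyano on an aromatic carbon.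

Neither measured step touches that carbon. With (cyanomethyl)carbonyl in place of hydrogen on a nitrogen, the number moves by a 2.0-fold higher number from compound 1 to compound 2 (0.30 log units; within the scatter). With hydrogen in place of chloro on an aromatic carbon, it moves by a 12-fold higher number from compound 1 to compound 3 (1.07 log units; beyond the scatter). Among the compounds with values here, the first step is small and the second large, but both lie elsewhere in the molecule, and no measured pair tests a replacement of the cyano group. The large step shows only that one change among these compounds can shift the number substantially in this assay, so the range should stay wide. The expectation therefore rests on compound 3 at 8280 nM, with no step beyond the scatter and no favoured direction. The estimated change is a 1.1-fold lower number from compound 3 to compound 4 (0.04 log units; within the scatter). For compound 4 the expected value is 7500 nM, within an estimated range from 2300 nM to 25000 nM.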

Compound 4, half-maximal inhibitory concentration: 6800 nM
Beside the measured number, compound 4's estimate is 1.1-fold (0.04 log units) above it; the measured number falls inside the stated range.
By their numbers in this assay, from the lowest: compounds 1 and 2 (each within the scatter of the next); then compounds 4 and 3 (each within the scatter of the next).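

In this assay, within the data shown here, the first step at this aromatic carbon, ethoxycarbonyl in place of cyano, is a 1.2-fold lower number from compound 3 to compound 4 (0.09 log units; within the scatter) and so lies within the scatter. Among these compounds, the shared core therefore keeps its number in this assay when the nitrile gives way to the ester, a change that the earlier steps, both made elsewhere in the molecule, could not test. Nothing at hand explains why the number holds, and no measurement of any property of either group bears on it.

From the compounds shown here alone, the result comes from a single pair with hydrogen on the anilide ring, so it remains open whether the same exchange would leave the number unmoved with chloro in that place, as in compound 1 at 700 nM, the lowest value here alongside compound 2. Also open is how far this carbon accepts other replacements, such as a carboxylic acid, a primary amide or an ester with a longer chain, since the compounds shown hold only cyano and ethoxycarbonyl there.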